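Amidoxime in place of acetyl on the chromene core

The compounds below may be only part of what the source reports. "The series", "measured", "known", "first", "only" and "open" are said of these compounds alone.

Measured compounds:
Compound 1, `CC(=O)c1ccc2c(c1)C(n1ccccc1=O)=CC(C)(C)O2`: 6.65
Compound 2, `CC1(C)C=C(n2ccccc2=O)c2cc(C(=O)c3cccs3)ccc2O1`: 5.84

For the measured compounds named here, in a functional assay (trachea) with Rattus norvegicus as the target (on this read-out higher numbers stand for higher potency (the scale is a negative logarithm) and lower numbers for lower potency), compound 1 gives 6.65 and stands highest of the two numbers known; its nearest neighbour is compound 2, which in this assay gives 5.84. Going by the values given here, the one step known, a number 0.81 log units lower from compound 1 to compound 2 (beyond the scatter), replaces the methyl on the carbonyl carbon with thiophen-2-yl while the carbonyl itself stays.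

Compound 3, `CC1(C)C=C(n2ccccc2=O)c2cc(C(=N)NO)ccc2O1`, differs from compound 1 as follows: a group of 4 heavy atoms (1 carbon, 2 nitrogen, 1 oxygen; no ring) in place of a group of 3 heavy atoms (2 carbon, 1 oxygen; no ring), on an aromatic carbon. Among the compounds with values here, the group that enters, with its three hydrogen-bond donors, has no counterpart among the measured compounds; the step of a number 0.81 log units lower from compound 1 to compound 2 (beyond the scatter) changes what hangs on the carbonyl carbon rather than the carbonyl itself, so it bears on this change only loosely. It does show that altering the substituent at this aromatic carbon can move the read-out beyond the scatter, in the lower direction. A modest loss is therefore expected, with wide uncertainty.

For compound 3 in this assay the expected value is 6.1, within 5.3 to 6.9, a step of a number 0.55 log units lower from compound 1 to compound 3 (beyond the scatter).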

Compound 3, logarithm of the reciprocal of the active concentration, log(1/C): 5.51
For compound 3 the middle estimate is 0.59 log units above the measured one; measured number inside the range.
By their numbers in this assay, from the lowest: compound 3; then compound 2; then compound 1.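

In this assay, for the compounds shown here, the earlier compounds changed only what hangs on the carbonyl carbon, whereas compound 3 shows what happens when the acetyl on this aromatic carbon gives way to a group with no carbonyl at all: a number 1.14 log units lower from compound 1 to compound 3 (beyond the scatter). The new group also falls short of the thiophen-2-yl ketone, with a number 0.33 log units lower from compound 2 to compound 3 (beyond the scatter), so compound 3 is the least potent of the three and both compounds that keep the carbonyl stand above it. Nothing available here accounts for this loss.

Going by these compounds alone, what remains open is whether the drop follows from removing the carbonyl or from the particular group that enters, since compound 3 changes both at once and is the only compound without a carbonyl at this position. A carboxamide, a nitrile or an O-methyl amidoxime on the same aromatic carbon would help separate these two readings, and would show whether any replacement for the carbonyl can come close to the value of compound 1 at 6.65.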